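Cyclopropyl at the two-carbon position of the benzimidazole series

The source may hold more compounds than are shown below. What is called first, only, known or untested is meant among the compounds shown, and "the series" means these compounds.

Working notes on a series that shares one core and differs only in the substituent on the aromatic carbon of the five-membered ring. Compound 1 `CCCCOC(=O)NS(=O)(=O)c1ccc(CCC)cc1-c1ccc(Cn2c(C3CCCCC3)nc3ccccc32)cc1` carries cyclohexyl there and in an assay on membranes from HEK293 cells for displacement of a labelled ligand from Type-2 angiotensin II receptor (Homo sapiens), read by radioligand binding (on this read-out lower numbers stand for stronger inhibition and higher numbers for weaker inhibition), compound 1 gives 130 nM. Compound 2 `CCCCOC(=O)NS(=O)(=O)c1ccc(CCC)cc1-c1ccc(Cn2c(C)nc3ccccc32)cc1` carries methyl and in this assay compound 2 gives 9.4 nM. Compound 3 `CCCCOC(=O)NS(=O)(=O)c1ccc(CCC)cc1-c1ccc(Cn2c(C(C)(C)C)nc3ccccc32)cc1` carries tert-butyl and in this assay compound 3 gives 5.3 nM, the lowest number of the three; compound 2 sits within the scatter of it, whereas compound 1 lies well beyond it.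

Compound 4 `CCCCOC(=O)NS(=O)(=O)c1ccc(CCC)cc1-c1ccc(Cn2c(C3CC3)nc3ccccc32)cc1` is the next member: cyclopropyl in place of tert-butyl on an aromatic carbon.

Among the measured compounds shown here, the steps that bear on this change are a 25-fold lower number from compound 1 to compound 3 (1.39 log units; beyond the scatter) and a 1.8-fold lower number from compound 2 to compound 3 (0.25 log units; within the scatter), with a 14-fold lower number from compound 1 to compound 2 (1.14 log units; beyond the scatter) as the third. Taken together they show that a large ring gives the weaker number while methyl and tert-butyl stand close to each other. Cyclopropyl is a ring, but with three carbon atoms it is nearer in size to methyl and tert-butyl than to cyclohexyl, so a small or no step beyond the scatter is expected in this assay; the estimated step is a 1.7-fold higher number from compound 3 to compound 4 (0.23 log units; within the scatter), leaning toward a slightly higher number. For compound 4 the expected value in this assay is therefore 9 nM, estimated to fall between 3 nM and 30 nM.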

Compound 4, inhibition constant: 31 nM
The estimate for compound 4 lay 3.4-fold (0.54 log units) below the measured number, and the stated range ends below it.
By their numbers in this assay, from the lowest: compounds 3 and 2 (each within the scatter of the next); then compound 4; then compound 1.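

In this assay cyclopropyl does not join methyl and tert-butyl at this position: there is a 5.8-fold higher number from compound 3 to compound 4 (0.77 log units; beyond the scatter) and a 3.3-fold higher number from compound 2 to compound 4 (0.52 log units; beyond the scatter), yet also a 4.2-fold lower number from compound 1 to compound 4 (0.62 log units; beyond the scatter), so compound 4 takes an intermediate place that the earlier close pair and distant cyclohexyl compound did not reveal. Heavy-atom count alone does not order these groups, since cyclopropyl has 3 heavy atoms against 4 for tert-butyl and still gives the higher number; across these four compounds, the two with a ring on this aromatic carbon, compound 4 and compound 1, both give higher numbers than the two without one, and no compound shown goes against this. Nothing available here explains this order.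

The compounds shown leave open whether the number climbs steadily with ring size from compound 4 to compound 1, which cyclobutyl and cyclopentyl would address. They also leave open whether the presence of a ring itself tracks with the higher number, which isopropyl as an open-chain group of similar size would test, and how a group carrying an amine would behave here.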